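From 2-Ethylphenyl to 4-Fluorophenyl on the Sulfonate Oxygen

The compounds below may be only part of what the source reports. "The series", "measured", "known", "first", "only" and "open" are said of these compounds alone.

Two measured compounds share one core and differ only in the group sitting on the oxygen whose other neighbour is the sulfonyl sulfur. Compound 1 `CCc1ccccc1OS(=O)(=O)c1ccc(N2CCN(C)C2=O)cc1` carries 2-ethylphenyl there; in a functional assay on MCF7 cells (Homo sapiens) for antiproliferative activity, read by sulforhodamine B assay, with a stated time of 48 h (on this read-out higher numbers stand for weaker inhibition and lower numbers for stronger inhibition), compound 1 gives 26000 nM, the highest of the two numbers, so it is the weaker inhibitor of the pair. Compound 2 `COc1cc(OC)cc(OS(=O)(=O)c2ccc(N3CCN(C)C3=O)cc2)c1` carries a different group at the same oxygen, and in this assay compound 2 gives 230 nM, a far lower number, well beyond the usual scatter.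

Compound 3 `CN1CCN(c2ccc(S(=O)(=O)Oc3ccc(F)cc3)cc2)C1=O` has not yet been measured. Compared with compound 1 it differs by 4-fluorophenyl in place of 2-ethylphenyl on an oxygen. Going by the values given here, no step between measured compounds matches this exact change, so the expectation rests on the two values alone: compound 1 stands far above compound 2, showing that this position allows large swings. Compound 3 is expected to give a lower number than compound 1 in this assay, a step of an 8.7-fold lower number from compound 1 to compound 3 (0.94 log units; beyond the scatter) of moderate size, beyond the scatter yet short of the gap to compound 2. The estimate for compound 3 is 3000 nM, with a range from 500 nM to 20000 nM.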

Compound 3, half-maximal inhibitory concentration: > 100000 nM
Compound 3 was reported as a limit; the forecaster's own chance of this, stated with the estimate: 5%; middle value at least 33-fold (1.52 log units) from the limit.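

The value for compound 3 in this assay is a limit of the assay and not a number: the limit of > 100000 nM in this assay, at which 1 of the 3 values shown sits.

Even read as a limit, putting 4-fluorophenyl in place of 2-ethylphenyl on the oxygen whose other neighbour is the sulfonyl sulfur gives an at least 3.8-fold higher number from compound 1 to compound 3 (0.58 log units; beyond the scatter), so the number moves up, and how far it moves past that minimum cannot be read. Compound 1 had looked like the weak end of this small set, but this step shows that the number at this position can climb further still, and since both groups hold one six-membered aromatic ring of carbon only, keeping such a ring on the oxygen does not by itself preserve activity.

This step changes two things at once, the ethyl group becoming a fluorine and the place of that group on the ring changing, so the compounds shown cannot separate the two; 2-fluorophenyl, 4-ethylphenyl and plain phenyl would be the groups to tell them apart. What sets the large differences among the groups on this oxygen also stays open, since nothing shown here speaks to a cause.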